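This account rests on a few compounds, and the source may have more. Where it says the series, first, only, none or still open, it means among the compounds named here.

Readings in an ADME assay on Raji cells (Homo sapiens) for cytotoxicity, read by CellTiter-Glo and resazurin assay, with a stated time of 72 h; a higher number here means that more compound is needed for the effect, a lower number that less compound is needed:
- Compound 1 `CC(C)N(Cc1cccc(OCCCCCC(=O)O)c1)C(=O)c1ccc(-c2cccc(N(C)C)c2)cc1`: > 26000 nM, a limit
- Compound 2 `CC(C)N(Cc1cccc(OCCCCCC(=O)O)c1)C(=O)c1ccc(-c2ccc3c(c2)OCCO3)cc1`: > 21900 nM, a limit
- Compound 3 `CC(C)N(Cc1cccc(OCCCCCC(=O)O)c1)C(=O)c1ccc(-c2c[nH]c3ccccc23)cc1`: > 26000 nM, a limit

Compound 3 has no number of its own in this assay, only the limit > 26000 nM. The other two compounds are also held at limits, so no numeric reading exists for the series. The readings fall at two limits: the limit of > 26000 nM in this assay, at which 2 of the 3 values shown sit, and (the limit of > 21900 nM in this assay, at which 1 of the 3 values shown sits).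

The next compound is compound 4 `CC(C)N(Cc1cccc(OCCCCCC(=O)O)c1)C(=O)c1ccc(-c2ccc(Cl)c(Cl)c2)cc1`, which carries 3,4-dichlorophenyl in place of 1H-indol-3-yl on an aromatic carbon, para to a large group: 3,4-dichlorophenyl in place of 1H-indol-3-yl on an aromatic carbon.

Three measured steps exchange the group at this same place: a step that the two limits leave unreadable from compound 1 to compound 2, a step that the two limits leave unreadable from compound 1 to compound 3 and a step that the two limits leave unreadable from compound 2 to compound 3. None of them has a readable size, so they give no measured guide to the size or direction of the new step. All three compounds remained at limits across these exchanges, so a further limit is the likeliest outcome for compound 4. No step beyond the usual scatter is expected, and no direction is predicted. The expected step is a number no higher from compound 3 to compound 4 (the limit leaves the size open). The estimate for compound 4 is 26000 nM, with an expected range of 10000 nM to 50000 nM.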

Compound 4, half-maximal effective concentration: > 26000 nM
Compound 4 ended at the assay's limit; the forecaster's own chance of this, stated with the estimate: 75%; the middle value sits exactly at the limit.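

In this assay, compound 4 gives > 26000 nM, a limit, so no step between compound 4 and compound 1, compound 2 or compound 3 can be read: the limit of > 26000 nM in this assay, at which 3 of the 4 values shown sit.

The compounds shown leave open what numeric reading any of the four would give in this assay, and whether exchanging the group at this place shifts that reading at all.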